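From trifluoroethoxy to tetrafluoroethoxy on compound 2

The compounds below may be only part of what the source reports. "The series", "measured", "known", "first", "only" and "open" are said of these compounds alone.

In a physicochemical assay for acid dissociation, compound 2 (`COc1ccnc(C[S+]([O-])c2nc3cc(OCC(F)(F)F)ccc3[nH]2)c1OC`) gives 3.9 and stands at the low end of the three numbers in hand. Compound 1 (`COc1c(C)cnc(C[S+]([O-])c2nc3cc(OC(F)F)ccc3[nH]2)c1C`) gives 4.16 and lies within the scatter of compound 2. Compound 3 (`COc1ccnc(C[S+]([O-])c2nc3cc(OCC(F)(F)F)ccc3[nH]2)c1C`) gives 4.97 and stands apart from both. Methyl in place of methoxy on an aromatic carbon produces a number 1.07 log units higher from compound 2 to compound 3 (beyond the scatter) and this is the only measured step that differs in one place.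

Compound 4 (`COc1ccnc(C[S+]([O-])c2nc3cc(OC(F)(F)C(F)F)ccc3[nH]2)c1OC`) has not yet been measured. It carries 1,1,2,2-tetrafluoroethyl in place of 2,2,2-trifluoroethyl on an oxygen on an aromatic ring. Going by the values given here, the one measured step leaves that group untouched, so no measured step bears directly on this change. Compound 1 differs from compound 2 in more than one place and cannot isolate it. In this assay the estimated step is a number 0.10 log units lower from compound 2 to compound 4 (within the scatter) and so none beyond the scatter is expected. For compound 4 the estimated value is 3.8 (expected range 3.4 to 4.2).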

Compound 4, acid dissociation constant: 3.86
Compound 4: the middle estimate sits 0.06 log units below what was measured; the measured number falls inside the stated range.
By their numbers in this assay, from the lowest: compounds 4, 2 and 1 (each within the scatter of the next); then compound 3.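

In this assay, 1,1,2,2-tetrafluoroethyl in place of 2,2,2-trifluoroethyl on an oxygen on an aromatic ring gives a number 0.04 log units lower from compound 2 to compound 4 (within the scatter). Going by these compounds alone, this is the first reading of a one-place change in this group: the only earlier step, a number 1.07 log units higher from compound 2 to compound 3 (beyond the scatter), left the group untouched. At this position, then, the exchange of one fluorinated ethyl group for the other, with one more fluorine among its heavy atoms, leaves the read-out within the scatter, and no measurement at hand speaks to what lies behind this result.

As far as these compounds go, whether an unfluorinated ethyl group, a longer chain or an amine on this oxygen would also leave the number within the scatter remains open. So does whether the same exchange would read alike on compound 3, which carries methyl in place of methoxy.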